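Aryl swap on the double-bonded chain, antiproliferative series

A few compounds are considered here, and "the series" means these few. Any claim that something is new, unique, unknown or untested is made for them only; others in the source may bear on it.

Measured so far:
compound 1 `COc1cccc(/C=C/C(=O)c2ccc(OC)c3c2OC(C)(C)C=C3)c1`: > 10000 nM
compound 2 `COc1cc(OC)c(OC)cc1/C=C/C(=O)c1ccc(OC)c2c1OC(C)(C)C=C2`: > 10000 nM
compound 3 `COc1ccc(C(=O)/C=C/c2ccc3ccccc3n2)c2c1C=CC(C)(C)O2`: 2250 nM

In a functional assay on SW-620 cells (Homo sapiens) for antiproliferative activity, read by MTT assay, with a stated time of 24 h (a higher number here means a weaker inhibitor, a lower number a stronger inhibitor), compound 1 returns only a limit, > 10000 nM. Compound 2 likewise returns only a limit, > 10000 nM. For the measured compounds named here, compound 3 is the single compound with a number, 2250 nM. Going by the values given here, compound 1 thus stands at the limit of > 10000 nM in this assay, at which 2 of the 3 values shown sit, and no step between measured compounds is available.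

Compound 4 `COc1ccc(C(=O)/C=C/c2ccsc2)c2c1C=CC(C)(C)O2` is not yet measured. It differs from compound 1 by thiophen-3-yl in place of 3-methoxyphenyl on a double-bonded chain carbon bound to a double-bonded chain carbon. With compound 1 sitting at a limit, no direction is supported by the data. Compound 4 is expected to stay weak, near the limit, with an estimated step of an at least 1.1-fold lower number from compound 1 to compound 4 (0.04 log units; that floor lies within the scatter); its value is estimated at 9000 nM, between 3000 nM and 30000 nM.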

Compound 4, half-maximal inhibitory concentration: > 10000 nM
Compound 4: no number, only a limit; the forecaster's own chance of this, stated with the estimate: 55%; middle value at least 1.1-fold (0.04 log units) from the limit.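

In this assay no step can be read between compound 1 and compound 4, because both return only a limit: the limit of > 10000 nM in this assay, at which 3 of the 4 values shown sit.

The compounds shown leave open whether thiophen-3-yl in place of 3-methoxyphenyl shifts the value at all, and in which direction.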